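The compounds below may be only part of what the source reports. "The series", "measured", "known", "first", "only" and "open" are said of these compounds alone.

Compound 1 `COc1ccc(C2=NN(c3ccccc3)C(c3ccc(C)cc3)C2S(=O)(=O)CC2=NCCO2)cc1` and compound 2 `COc1ccc(C2=NN(c3ccccc3)C(c3ccc(C)cc3)C2S(=O)(=O)CC2=NCCS2)cc1` share one core and differ only at the saturated chain carbon bound to the sulfonyl sulfur. In a functional assay, read by Griess assay, with a stated time of 150 min, tested at 100 ug/mL (a higher number here means a stronger effect of the compound at the concentration tested, a lower number a weaker effect), compound 1 gives 70.5%, while compound 2 gives 50.7%. The change is a group of 5 heavy atoms (3 carbon, 1 nitrogen, 1 oxygen; one five-membered non-aromatic ring with 2 hetero atoms) in place of a group of 5 heavy atoms (3 carbon, 1 nitrogen, 1 sulfur; one five-membered non-aromatic ring with 2 hetero atoms), on a saturated chain carbon bound to a sulfonyl sulfur, and it makes a step of a number 19.8 percentage points higher from compound 2 to compound 1 (beyond the scatter).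

Compound 3 `COc1ccc(-c2noc(-c3ccc(C)cc3)c2S(=O)(=O)CC2=NCCS2)cc1` rests on a different core; the difference between the two cores is not broken down here. In this assay compound 3 gives "not active" (no number reported), with no number given.

Compound 4 `COc1ccc(-c2noc(-c3ccc(C)cc3)c2S(=O)(=O)CC2=NCCO2)cc1` carries the same change on the core of compound 3, (a group of 5 heavy atoms (3 carbon, 1 nitrogen, 1 oxygen; one five-membered non-aromatic ring with 2 hetero atoms) in place of a group of 5 heavy atoms (3 carbon, 1 nitrogen, 1 sulfur; one five-membered non-aromatic ring with 2 hetero atoms), on a saturated chain carbon bound to a sulfonyl sulfur). Compound 3 has no number. The change cannot be anchored there. The modest rise a number 19.8 percentage points higher from compound 2 to compound 1 (beyond the scatter) suggests some gain. Compound 4 is therefore expected to give 15%, between 0% and 40%.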

Compound 4, a percentage reported as activity, at one concentration (the size of the read-out at that concentration, not a potency): 76.2%
Compound 4: the middle estimate sits 61.2 percentage points below what was measured; the measured number lies above the stated range.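

In this assay, for the compounds shown here, compound 3 has no number, so no step to compound 4 can be read. How large the change is on this core stays open, and no measurement shown here bears on the result.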